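A few compounds are considered here, and "the series" means these few. Any claim that something is new, unique, unknown or untested is made for them only; others in the source may bear on it.

Measured in a functional assay on DU-145 cells (Homo sapiens) for inhibition, read by trypan blue exclusion, with a stated time of 96 h (a lower number here means a stronger inhibitor of growth, a higher number a weaker inhibitor of growth), the compounds read as follows
- compound 1 `O=C(/C(=C\c1ccc(O)c([N+](=O)[O-])c1)SCc1ccccc1Cl)c1ccc(Cl)cc1` gives 10000 nM
- compound 2 `Cc1cc(C)cc(/C=C(\C(=O)c2ccc(Br)cc2)S(=O)(=O)Cc2ccc(F)cc2)c1` gives 10000 nM
- compound 3 `COc1ccc(/C=C(/SCc2ccc(Cl)cc2)C(=O)c2ccc(Br)cc2)cc1` gives 10000 nM

Compound 2 stands level with compound 1 and compound 3, all three reading the same at the digits given. The move to compound 4 `Cc1ccc(C)c(/C=C(\C(=O)c2ccc(Br)cc2)S(=O)(=O)Cc2ccc(F)cc2)c1` is a single exchange, 2,5-dimethylphenyl in place of 3,5-dimethylphenyl on a double-bonded chain carbon bound to a double-bonded chain carbon. Among the measured compounds shown here, no two measured compounds differ in one place alone, so the data give no direct guide to this exchange. With compound 2 at 10000 nM no step beyond the scatter is expected in this assay in either direction. The estimated step (a 1.1-fold lower number from compound 2 to compound 4 (0.05 log units; within the scatter)) is correspondingly small. For compound 4 the estimate is 9000 nM (expected range 3000 nM to 15000 nM).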

Compound 4, concentration for 50% growth inhibition: 1000 nM
Compound 4: middle estimate off by 9.0-fold (0.95 log units), on the high side; the whole stated range lies above it.
By their numbers in this assay, from the lowest: compound 4; then compounds 1, 2 and 3 (each within the scatter of the next).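

In this assay, 2,5-dimethylphenyl in place of 3,5-dimethylphenyl on a double-bonded chain carbon bound to a double-bonded chain carbon gives a 10-fold lower number from compound 2 to compound 4 (1.00 log units; beyond the scatter) and so shows that this position responds to a change in how the same atoms are joined. The earlier compounds shown here included no pair differing in one place and could not show this. No evidence here bears on the reason for the step.

On these data alone, it remains open whether an amine or a carboxylic acid on this phenyl ring would retain the gain. As far as these compounds go, it is also open whether the same exchange would produce a similar step on the cores of compound 1 and compound 3.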